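A few compounds are considered here, and "the series" means these few. Any claim that something is new, unique, unknown or untested is made for them only; others in the source may bear on it.

Measured in a functional assay on A549 cells (Homo sapiens) for cytotoxicity, read by MTT assay, with a stated time of 4 days; a lower number here means a stronger inhibitor, a higher number a weaker inhibitor:
Compound 1 `COc1cc(C[C@H]2C(=O)OC[C@@H]2Cc2ccc(OC)c(OC)c2)ccc1N` gives 2850 nM
Compound 2 `COc1cc(C[C@H]2C(=O)OC[C@@H]2Cc2ccc(OC)c(OC)c2)ccc1NC(=O)c1ccccc1` gives > 50000 nM (a limit)
Compound 3 `CCC(=O)Nc1ccc(C[C@H]2C(=O)OC[C@@H]2Cc2ccc(OC)c(OC)c2)cc1OC` gives > 50000 nM (a limit)

Compound 3 stands at the limit of > 50000 nM in this assay, at which 2 of the 3 values shown sit, so it offers a limit and no number. Next comes compound 4 `COc1ccc(Nc2ccc(C[C@H]3C(=O)OC[C@@H]3Cc3ccc(OC)c(OC)c3)cc2OC)cc1`, with 4-methoxyphenyl in place of propanoyl on a nitrogen on an aromatic ring. The nearest evidence is the two changes on that nitrogen, an at least 17-fold higher number from compound 1 to compound 2 (1.24 log units; beyond the scatter) and an at least 17-fold higher number from compound 1 to compound 3 (1.24 log units; beyond the scatter), both large. The remaining comparison, a step that the two limits leave unreadable from compound 2 to compound 3, adds nothing. Neither large step tests an aryl group on the nitrogen, so only a partial return toward compound 1 is expected, with a lower number in this assay. The expected step is an at least 3.3-fold lower number from compound 3 to compound 4 (0.52 log units; beyond the scatter). For compound 4 the estimate is 15000 nM, with an expected range of 3000 nM to 50000 nM.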

Compound 4, half-maximal inhibitory concentration: > 50000 nM
Compound 4: no number, only a limit; the forecaster's own chance of this, stated with the estimate: 40%; middle value at least 3.3-fold (0.52 log units) away from the limit.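

In this assay compound 4 gives > 50000 nM, which is a limit and not a number. With 4-methoxyphenyl in place of hydrogen on the nitrogen, the result is an at least 17-fold higher number from compound 1 to compound 4 (1.24 log units; beyond the scatter), so the loss seen with benzoyl and propanoyl also occurs with a group carrying no carbonyl. The steps among compound 2, compound 3 and compound 4 cannot be read: the limit of > 50000 nM in this assay, at which 3 of the 4 values shown sit.

On these data alone, whether a methyl group on that nitrogen keeps a value short of the limit remains open. Also open, as far as these compounds go, is what a hydroxyl group in place of the amine would give.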